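The source may report more compounds than this note shows. Statements on the series, on what has been measured and on what is new or still open speak of the compounds shown alone.

Three compounds have been measured so far:

compound 1, `COc1ccc(S(=O)(=O)N(Cc2ccc(C(C)C)cc2)[C@H](C)C(=O)NO)cc1`: 230 nM
compound 2, `COc1ccc(S(=O)(=O)N(Cc2ccc(SC)cc2)[C@H](C)C(=O)NO)cc1`: 80 nM
compound 3, `COc1ccc(S(=O)(=O)N(Cc2cc(F)cc(F)c2)[C@H](C)C(=O)NO)cc1`: 140 nM

All three share one core and differ only in the group carried on the saturated chain carbon bound to the sulfonamide nitrogen. In an assay on isolated protein for inhibition of bone morphogenetic protein 1 (Homo sapiens) (on this read-out higher numbers stand for weaker inhibition and lower numbers for stronger inhibition), compound 3 stands with the second highest number of the three; its gap to compound 1, a 1.6-fold lower number from compound 1 to compound 3 (0.22 log units; within the scatter), and its gap to compound 2, a 1.8-fold higher number from compound 2 to compound 3 (0.24 log units; within the scatter), both fall within the scatter, so no order among the three can be read from them. Compound 4, `COc1ccc(S(=O)(=O)N(Cc2cnc(Cl)s2)[C@H](C)C(=O)NO)cc1`, has not yet been measured. It differs from compound 3 as follows: 2-chloro-1,3-thiazol-5-yl in place of 3,5-difluorophenyl on a saturated chain carbon bound to a sulfonamide nitrogen. Among the measured compounds shown here, two measured steps exchange the whole aromatic group at this place, and both stayed within the scatter; the only step beyond it, a 2.9-fold lower number from compound 1 to compound 2 (0.46 log units; beyond the scatter), was a change of substituent on that ring and was modest. For the measured compounds named here, none of the measured compounds carries a ring with hetero atoms at this place, so the entering group has no direct precedent. The change is therefore expected to be small, a 1.2-fold higher number from compound 3 to compound 4 (0.08 log units; within the scatter), with no firm lean in either direction. Compound 4 is estimated at 170 nM, in a range from 70 nM to 400 nM.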

Compound 4, half-maximal inhibitory concentration: 180 nM
Compound 4: the middle estimate sits 1.1-fold (0.02 log units) below what was measured; measured number inside the range.
By their numbers in this assay, from the lowest: compounds 2, 3, 4 and 1 (each within the scatter of the next, the first and the last beyond it).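

In this assay, the first ring with hetero atoms on a saturated chain carbon bound to a sulfonamide nitrogen stays level with two carbon-only rings: a 1.3-fold higher number from compound 3 to compound 4 (0.11 log units; within the scatter) and a 1.3-fold lower number from compound 1 to compound 4 (0.11 log units; within the scatter). The exchange of a six-membered for a five-membered aromatic ring, with hydrogen-bond acceptors entering, thus leaves no readable change against those two compounds, and only a 2.3-fold higher number from compound 2 to compound 4 (0.35 log units; beyond the scatter) goes beyond the scatter, and then modestly. Nothing available explains these numbers.

The ring and its chlorine entered together, so the compounds shown do not separate what each contributes. Going by these compounds, whether an amine or a methyl in place of the chlorine on the 1,3-thiazol-5-yl ring would move the number in either direction remains open.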